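Reducing the Imine Link: From Compound 3 to Compound 4

The compounds below may be only part of what the source reports. "The series", "measured", "known", "first", "only" and "open" are said of these compounds alone.

Three compounds sharing a long saturated chain, an amide and a hydroxymethyl-bearing carbon have been measured in a functional assay on cells (Homo sapiens) for cytotoxicity, read by MTT assay, with a stated time of 24 h; a higher number here means a weaker inhibitor, a lower number a stronger inhibitor. Compound 1 `CCCCCCCCCCCCCCNC(=O)[C@H](CO)/N=C/c1ccc([N+](=O)[O-])cc1` gives 217000 nM. Compound 2 `CCCCCCCCCCCCCCNC(=O)[C@H](CO)/N=C/c1cccc(Cl)c1` gives 24100 nM. Compound 3 `CCCCCCCCCCCCCCNC(=O)[C@H](CO)/N=C/c1ccc(O)cc1` gives 19300 nM, the lowest of the three numbers; its distance to compound 2 lies within the scatter, while the step of an 11-fold lower number from compound 1 to compound 3 (1.05 log units; beyond the scatter) stands well beyond it, as does the step of a 9.0-fold lower number from compound 1 to compound 2 (0.95 log units; beyond the scatter).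

Compound 4 `CCCCCCCCCCCCCCNC(=O)[C@H](CO)NCc1ccccc1OC` is the next step. Its change from compound 3 is a group of 10 heavy atoms (8 carbon, 1 nitrogen, 1 oxygen; one six-membered aromatic ring of carbon only) in place of a group of 9 heavy atoms (7 carbon, 1 nitrogen, 1 oxygen; one six-membered aromatic ring of carbon only), on a saturated chain carbon bound to a carbonyl carbon and a saturated chain carbon. The group that leaves carries one double bond outside aromatic rings; the group that enters carries none. Among the measured compounds shown here, none of the measured steps touches this part of the molecule: they all alter only what sits on the aromatic ring, and the one step that compares two aromatic patterns with different substituents, from compound 2 to compound 3, stays within the scatter. There is therefore no measured guide for this change, and a wide range is appropriate. Compound 4 is expected to land near compound 3, with the step of a 1.3-fold higher number from compound 3 to compound 4 (0.11 log units; within the scatter) estimated as small and uncertain in direction, giving an estimate of 25000 nM within a range from 8000 nM to 80000 nM.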

Compound 4, half-maximal inhibitory concentration: 100000 nM
Beside the measured number, compound 4's estimate is 4.0-fold (0.60 log units) below it, and the stated range ends below it.
By their numbers in this assay, from the lowest: compounds 3 and 2 (each within the scatter of the next); then compound 4; then compound 1.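

Among the compounds shown here, until now, every measured step in this assay changed only what sits on the aromatic ring, with the carbon-nitrogen double bond left in place, so compound 4 is the first to show that altering the link itself can move the number. The (2-methoxybenzyl)amino group, which has no double bond outside the ring, gives a 5.2-fold higher number from compound 3 to compound 4 (0.71 log units; beyond the scatter), a weaker result by a margin the ring changes between compound 2 and compound 3 did not produce. The step of a 4.1-fold higher number from compound 2 to compound 4 (0.62 log units; beyond the scatter) points the same way, so the rise holds against both of the lowest-numbered compounds, although compound 4 still has a lower number than compound 1. Nothing measured here explains why the number rises at this position.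

As far as these compounds go, compound 4 differs from compound 3 in two ways at once, losing the double bond and carrying a methoxy group on its ring in place of the hydroxy group, so the size of each contribution remains unknown. A plain benzylamino group at this position, or a methoxy-bearing ring kept on the double-bonded link, would help separate the two.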